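This account rests on a few compounds, and the source may have more. Where it says the series, first, only, none or still open, it means among the compounds named here.

Measured so far, in a functional assay on CFPAC-1 cells (Homo sapiens) for antiproliferative activity, read by MTT assay, with a stated time of 72 h; on this read-out lower numbers stand for stronger inhibition and higher numbers for weaker inhibition:
- Compound 1 `CCCCCc1ccc(-c2cn(C[C@H](O)[C@H]3OC(=O)C(OCc4ccccc4)=C3OCc3ccccc3)nn2)cc1` gives 9890 nM.
- Compound 2 `COc1ccccc1-c1cn(C[C@H](O)[C@H]2OC(=O)C(OCc3ccccc3)=C2OCc2ccccc2)nn1` reaches only the limit of the assay, > 100000 nM.
- Compound 3 `Cc1ccc(-c2cn(C[C@H](O)[C@H]3OC(=O)C(OCc4ccccc4)=C3OCc3ccccc3)nn2)cc1` likewise reaches only the limit, > 100000 nM.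

Compound 3 therefore stands at the assay limit, with no number of its own; the limit of > 100000 nM in this assay, at which 2 of the 3 values shown sit, holds two of the three values shown. The not yet measured compound 4 `O=C1O[C@H]([C@@H](O)Cn2cc(-c3cc(F)cc(F)c3)nn2)C(OCc2ccccc2)=C1OCc1ccccc1` differs from compound 3 in one place: 3,5-difluorophenyl in place of 4-methylphenyl on an aromatic carbon. Going by the values given here, the steps that bear on this position are the changes at the same aromatic carbon. From compound 1 the two changes shown there both lose activity, an at least 10-fold higher number from compound 1 to compound 2 (1.00 log units; beyond the scatter) and an at least 10-fold higher number from compound 1 to compound 3 (1.00 log units; beyond the scatter), while the step that the two limits leave unreadable from compound 2 to compound 3 between two limits cannot be read. Both the 2-methoxyphenyl and the 4-methylphenyl ended at the limit, and only the 4-pentylphenyl gave a measurable number. The 3,5-difluorophenyl of compound 4 carries no chain like that of compound 1, so compound 4 is expected to stay close to the limit, with a number no higher from compound 3 to compound 4 (the limit leaves the size open) expected to be no step beyond the scatter. The estimate for compound 4 is 100000 nM, within 30000 nM to 300000 nM.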

Compound 4, half-maximal inhibitory concentration: 62400 nM
The estimate for compound 4 lay 1.6-fold (0.20 log units) above the measured number; low and high end bracket the measured number.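

Compound 4 is the only compound shown besides compound 1 that gives a number rather than a limit, so a measurable reading at this position does not require the 4-pentylphenyl. It still falls short of that group, with a 6.3-fold higher number from compound 1 to compound 4 (0.80 log units; beyond the scatter). Against the two compounds at a limit only floors can be read, an at least 1.6-fold lower number from compound 3 to compound 4 (0.20 log units; that floor lies within the scatter) and an at least 1.6-fold lower number from compound 2 to compound 4 (0.20 log units; that floor lies within the scatter), so neither step proves a real gain, and the step between those two limits cannot be read: the limit of > 100000 nM in this assay, at which 2 of the 4 values shown sit.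

From the compounds shown here alone, it remains open whether a 3,5-difluorophenyl that also carried a pentyl chain would give a lower number than either compound 1 or compound 4. How a propyl chain, a longer chain than pentyl, or an amine on the same phenyl ring would read is also unknown.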